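This account rests on a few compounds, and the source may have more. Where it says the series, first, only, none or still open, it means among the compounds named here.

Three compounds share one core and differ only in the ring carried by the amide. In a toxicity assay on HepG2 cells (Homo sapiens) for inhibition, read by CellTiter-Glo, with a stated time of 48 h (a lower number here means a stronger inhibitor, a higher number a weaker inhibitor), compound 2 `COc1ccc2nc(C)cc(OCC(=O)Nc3cccc(C)c3)c2c1` gives 39800 nM and is the weakest inhibitor of the three. Compound 1 `Cc1cc(C)cc(NC(=O)COc2cc(C)nc3ccc(C)cc23)c1` gives 15900 nM in this assay, and compound 3 `COc1ccc2nc(C)cc(OCC(=O)Nc3cc(C)c(OC)c(C)c3)c2c1` gives 7940 nM, both steps from compound 2 lying beyond the scatter. Compound 4 `COc1ccc2nc(C)cc(OCC(=O)Nc3ccc(Br)c(C)c3)c2c1` is not yet measured and differs from compound 2 by bromo in place of hydrogen on an aromatic carbon. Within the data shown here, no measured pair shows this exact change. Since compound 1 with 15900 nM and compound 3 with 7940 nM each carry more groups on that ring than compound 2 and give lower numbers, a modest step to a lower number is expected, a 2.5-fold lower number from compound 2 to compound 4 (0.40 log units; beyond the scatter). Compound 4 is therefore estimated at 16000 nM, within 5000 nM to 50000 nM.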

Compound 4, half-maximal inhibitory concentration: 15900 nM
Beside the measured number, compound 4's estimate is 1.0-fold (0.00 log units) above it; the range from low to high includes it.
By their numbers in this assay, from the lowest: compounds 3, 1 and 4 (each within the scatter of the next); then compound 2.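

In this assay, placing one bromo on the ring, ortho to a methyl group and para to a large group, gives a 2.5-fold lower number from compound 2 to compound 4 (0.40 log units; beyond the scatter). Among these compounds, no earlier pair differed in only one place, so this is the first change here that can be read alone, and it shows that this single atom at this position is enough to move the number beyond the scatter. Nothing measured here explains the step.

Going by these compounds, whether a chlorine, a methoxy group or an amine at this position would give a similar step stays open, and so does the effect of bromo elsewhere on the ring.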